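The source may hold more compounds than are shown below. What is called first, only, known or untested is meant among the compounds shown, and "the series" means these compounds.

Measured in a functional assay on SW-620 cells (Homo sapiens) for antiproliferative activity, read by CCK-8 assay and cell counting, with a stated time of 72 h; a lower number here means a stronger inhibitor, a higher number a weaker inhibitor:

- compound 1 `O=C(Nc1ccccc1)c1ccc(CCl)cc1`: 800 nM
- compound 2 `O=C(Nc1ccccc1)c1ccc(CO[N+](=O)[O-])cc1`: 800 nM
- compound 3 `CCc1ccc(C(=O)Nc2ccccc2)cc1`: > 100000 nM

The value of compound 3 is a limit of the assay and not a number. Compound 3 therefore stands at the limit of > 100000 nM in this assay, at which 1 of the 3 values shown sits. On these data alone, its true value in this assay is unknown, so any step that starts from it has an uncertain size.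

Compound 4 `O=C(Nc1ccccc1)c1ccc(CO)cc1` has hydroxy in place of methyl on a saturated chain carbon bound to an aromatic carbon, or ethyl to hydroxymethyl when cut one bond further out (hydroxy in place of methyl on a saturated chain carbon bound to an aromatic carbon).

Three measured steps change this same place. Two are large: an at least 120-fold higher number from compound 1 to compound 3 (2.09 log units; beyond the scatter) and an at least 120-fold higher number from compound 2 to compound 3 (2.09 log units; beyond the scatter). The third, no change at the digits printed from compound 1 to compound 2 (within the scatter), lies within the scatter, so chloro and nitrooxy cannot be told apart here. Hydroxy is neither of these groups, so the large steps offer only a loose guide. A lower number than the limit of compound 3 is expected, but a smaller gain than those large steps would suggest, and another limit remains quite possible.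

The expected change is an at least 4.0-fold lower number from compound 3 to compound 4 (0.60 log units; beyond the scatter). Compound 4 is estimated at 25000 nM, with an expected range of 3000 nM to 100000 nM.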

Compound 4, half-maximal inhibitory concentration: > 100000 nM
Compound 4: a limit, no number; the forecaster's own chance of this, stated with the estimate: 40%; middle value at least 4.0-fold (0.60 log units) away from the limit.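

In this assay compound 4 gives > 100000 nM, which is a limit of the assay and not a number. Hydroxy on this saturated chain carbon bound to an aromatic carbon therefore joins methyl at the weak end of the series, with an at least 120-fold higher number from compound 1 to compound 4 (2.09 log units; beyond the scatter) and an at least 120-fold higher number from compound 2 to compound 4 (2.09 log units; beyond the scatter) as the readable steps. The second step is the more telling one, as compound 2 and compound 4 both have an oxygen on this carbon and differ only in the nitro on that oxygen, so the oxygen alone does not keep the activity seen with nitrooxy.

The step between compound 3 and compound 4 cannot be read, because both end at the same limit, so methyl and hydroxy cannot be ranked here: the limit of > 100000 nM in this assay, at which 2 of the 4 values shown sit. On these data alone, it remains open whether only chloro and nitrooxy keep activity in this place, or whether another group, such as bromo, an amine or a methoxy, would do so too.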